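This account rests on a few compounds, and the source may have more. Where it says the series, first, only, none or still open, it means among the compounds named here.

Measured so far:
Compound 1, `CCc1ccc(NC(=O)c2cccc(/C=C3\CC(=O)N(c4ccccc4)C3=O)c2)cc1`: > 100000 nM in an ADME assay on SW480 cells (Homo sapiens) for cytotoxicity, read by MTT assay, with a stated time of 72 h; a lower number here means a stronger inhibitor, a higher number a weaker inhibitor
Compound 2, `CCOc1ccc(NC(=O)c2cccc(/C=C3\CC(=O)N(Cc4ccccc4)C3=O)c2)cc1`: 73200 nM in this assay

Going by the values given here, of the two values, compound 2 gives the only number; the entry for compound 1 is a limit of the assay, as noted in the limit of > 100000 nM in this assay, at which 1 of the 2 values shown sits. Compound 2 is therefore the one point from which to look ahead.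

Compound 3, `CCOc1ccc(NC(=O)c2cccc(/C=C3\CC(=O)N(c4ccccc4)C3=O)c2)cc1`, keeps the ethoxy group of compound 2 and changes the five-membered ring: phenyl in place of benzyl on an amide-type nitrogen in a ring. Among the compounds with values here, no measured pair follows this change. Compound 1 also carries phenyl on that ring nitrogen and reached only the limit, so a weak or absent effect is the more probable outcome. For compound 3 the expected step of a 1.4-fold higher number from compound 2 to compound 3 (0.14 log units; within the scatter) is small to moderate toward weaker inhibition, with a real chance that only a limit is reported. Compound 3 is expected at about 100000 nM, in the range from 40000 nM to 300000 nM.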

Compound 3, half-maximal inhibitory concentration: 91500 nM
For compound 3 the middle estimate is 1.1-fold (0.04 log units) above the measured one; low and high end bracket the measured number.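

Going by these compounds alone, with the ethoxy group held constant, this is the first measured pair that isolates the group on the ring nitrogen: a 1.3-fold higher number from compound 2 to compound 3 (0.10 log units; within the scatter). In this assay, phenyl in place of benzyl on an amide-type nitrogen in a ring therefore gives no change that can be told from repeat-measurement scatter. Compound 1 gives > 100000 nM, which is a limit and not a number, so ethoxy in place of ethyl on an aromatic carbon can be read only as a floor, and a small one: an at least 1.0-fold lower number from compound 1 to compound 3 (0.03 log units; that floor lies within the scatter).

From the compounds shown here alone, it remains open whether an amine or a carboxylic acid in place of ethoxy would move the number out of the scatter. The same question stands for a longer chain carrying the phenyl on the ring nitrogen.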